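The source may report more compounds than this note shows. Statements on the series, on what has been measured and on what is new or still open speak of the compounds shown alone.

Series notes. Compound 1 `CN1CCN(c2ccc(S(=O)(=O)Oc3ccc(F)cc3)cc2)C1=O` and compound 2 `CN1CCN(c2ccc(S(=O)(=O)Oc3ccc(Cl)cc3)cc2)C1=O` share one core; compound 3 `CCN1CCN(c2ccc(S(=O)(=O)Oc3cccc(F)c3)cc2)C1=O` and compound 4 `CCN1CCN(c2ccc(S(=O)(=O)Oc3cccc(Cl)c3)cc2)C1=O` share another, and the difference between the two cores is not broken down here. In a functional assay on HT-29 cells (Homo sapiens) for antiproliferative activity, read by sulforhodamine B assay, with a stated time of 48 h (on this read-out higher numbers stand for weaker inhibition and lower numbers for stronger inhibition), compound 1 gives > 100000 nM, which is a limit of the assay and not a number. Compound 2 gives 12000 nM in this assay. The change chloro in place of fluoro on an aromatic carbon thus makes an at least 8.3-fold lower number from compound 1 to compound 2 (0.92 log units; beyond the scatter). Compound 3 gives > 100000 nM in this assay, again a limit of the assay rather than a number. Going by the values given here, two of the three values so far sit at the limit of > 100000 nM in this assay, at which 2 of the 3 values shown sit. Compound 4 has not been measured. Its change from compound 3, (chloro in place of fluoro on an aromatic carbon), is the same kind of change as that from compound 1 to compound 2, but not the same: in the first pair the place is para to a large group, in the second meta to a large group. Compound 3 also starts at a limit, which leaves the starting point open. The expected step is an at least 5.0-fold lower number from compound 3 to compound 4 (0.69 log units; beyond the scatter), estimated to be of about the size of an at least 8.3-fold lower number from compound 1 to compound 2 (0.92 log units; beyond the scatter). Compound 4 is estimated at 20000 nM, between 5000 nM and 100000 nM, in this assay.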

Compound 4, half-maximal inhibitory concentration: 6800 nM
The estimate for compound 4 lay 2.9-fold (0.47 log units) above the measured number; measured number inside the range.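

In this assay, chloro in place of fluoro on an aromatic carbon goes again with a lower number, giving an at least 14-fold lower number from compound 3 to compound 4 (1.16 log units; beyond the scatter), so the direction seen on the core of compound 1 also holds on the core of compound 3, where the change lies meta to a large group. Set side by side, the two steps read: (the same change on two cores in this assay, an at least 8.3-fold lower number (0.92 log units; beyond the scatter) from compound 1 to compound 2 and an at least 14-fold lower number (1.16 log units; beyond the scatter) from compound 3 to compound 4; the limit leaves it open whether they differ). From the compounds shown here alone, both steps start from a limit and not from a number, so these two pairs show that the direction carries over but do not show that a particular size carries over, and the true size on either core stays unknown: (the limit of > 100000 nM in this assay, at which 2 of the 4 values shown sit).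

Each place on the aromatic ring appears here on one core only, so the contribution of the place cannot be separated from that of the core. Also open, going by these compounds, is how bromo or a nitrile on the same aromatic carbon, or a longer chain on the core, would read in this assay.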